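Capping the Ring Nitrogen of Compound 1

The source may report more compounds than this note shows. Statements on the series, on what has been measured and on what is new or still open speak of the compounds shown alone.

Compound 1 `CN1CCN(c2ccc(C3=NNC(c4ccc(N(C)C)cc4)C3)cc2)CC1` gives 31.2% in a functional assay on HCC1806 cells (Homo sapiens) for inhibition, read by sulforhodamine B assay, tested at 10 uM (on this read-out higher numbers stand for more inhibition at the one concentration tested (going by the name of the read-out) and lower numbers for less inhibition), the highest of the two numbers measured. Compound 2 `CC(=O)N1N=C(c2ccc(N3CCN(C)CC3)cc2)CC1c1ccc(N(C)C)cc1`, which carries acetyl in place of hydrogen on an amine nitrogen in a ring, gives -0.8% in this assay. That step, a number 32 percentage points lower from compound 1 to compound 2 (beyond the scatter), is the only measured one that bears on compound 3 `CN1CCN(c2ccc(C3=NN(S(C)(=O)=O)C(c4ccc(N(C)C)cc4)C3)cc2)CC1`, whose change from compound 1 is methylsulfonyl in place of hydrogen on an amine nitrogen in a ring. Since this change again replaces the same hydrogen, a drop of similar size is expected, namely a number 28.2 percentage points lower from compound 1 to compound 3 (beyond the scatter). Compound 3 is therefore estimated at 3%, within a range from -12% to 18%.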

Compound 3, a percentage reported as inhibition, at one concentration (the size of the read-out at that concentration, not a potency): -18.5%
For compound 3 the middle estimate is 21.5 percentage points above the measured one; the measured number lies below the stated range.
By their numbers in this assay, from the lowest: compound 3; then compound 2; then compound 1.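

A second replacement of the hydrogen on this ring nitrogen also lowers the number in this assay (a number 49.7 percentage points lower from compound 1 to compound 3 (beyond the scatter)), so the drop seen with acetyl is not limited to that one group. The two replacements also differ from each other (a number 17.7 percentage points lower from compound 2 to compound 3 (beyond the scatter)), which shows that the identity of the entering group matters, not only the loss of the hydrogen.

Going by these compounds, whether a plain methyl or a benzoyl group on this nitrogen would lower the number as well remains open. Nothing measured here explains why either replacement lowers the number.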